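Aziridinylquinone series: carbamate chain to benzyl

This account rests on a few compounds, and the source may have more. Where it says the series, first, only, none or still open, it means among the compounds named here.

Measured so far:
Compound 1 `CCCC1=C(N2CC2)C(=O)C(C(COC(N)=O)OC)=C(N2CC2)C1=O` gives 5.63 in a functional assay on L1210 cells (Mus musculus), with a stated time of 12 days; on this read-out lower numbers stand for lower potency and higher numbers for higher potency (the scale is a negative logarithm).
Compound 2 `CC1=C(N2CC2)C(=O)C(CC(C)OC(N)=O)=C(N2CC2)C1=O` gives 6.14 in this assay.
Compound 3 `O=C1C(CCO)=C(N2CC2)C(=O)C(CCO)=C1N1CC1` gives 6.54 in this assay.

Compound 2 stands second highest of the three numbers. Its nearest neighbour is compound 3, which lies higher by a margin beyond the scatter; furthest is compound 1, lower by a margin also beyond the scatter.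

Compound 4 `CC1=C(N2CC2)C(=O)C(Cc2ccccc2)=C(N2CC2)C1=O` is not yet measured. Relative to compound 2 the change is a group of 6 heavy atoms (6 carbon; one six-membered aromatic ring of carbon only) in place of a group of 6 heavy atoms (3 carbon, 1 nitrogen, 2 oxygen; no ring), on a saturated chain carbon bound to a double-bonded ring carbon.

Among the measured compounds shown here, no measured pair shows this kind of change, so no step can be read from the data. A modest step is expected, direction uncertain, and a number 0.24 log units lower from compound 2 to compound 4 (within the scatter) is the expected step. Compound 4 is estimated at 5.9, within 5.3 to 6.5.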

Compound 4, logarithm of the reciprocal of the active concentration, log(1/C): 4.85
Compound 4: the middle estimate sits 1.05 log units above what was measured; measured number outside the range, below it.
By their numbers in this assay, from the lowest: compound 4; then compound 1; then compound 2; then compound 3.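

At the place on a saturated chain carbon bound to a double-bonded ring carbon, replacing the open-chain group with phenyl gives a number 1.29 log units lower from compound 2 to compound 4 (beyond the scatter) in this assay. This first single-place step shows that the read-out depends strongly on the group at this place, even with the same count of heavy atoms entering and leaving. No measurement bears on the reason for this step.

This pair cannot separate the contribution of the phenyl ring from that of losing the hydrogen-bond donor and acceptors. From the compounds shown here alone, how an amine or a carboxylic acid at this place would read remains open.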